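This account rests on a few compounds, and the source may have more. Where it says the series, first, only, none or still open, it means among the compounds named here.

Working notes on the series, read in a functional assay on PC-3 cells (Homo sapiens) for antiproliferative activity, read by CCK-8 assay, with a stated time of 6 days; a higher number here means a weaker inhibitor, a lower number a stronger inhibitor. Compound 1 `CCN(c1cccc(-c2ccccc2)c1)c1ccc(C#N)c(Cl)c1` has no usable result, with the entry "not determined" (no result reported). Compound 2 `CCN(c1ccc(C#N)c(Cl)c1)c1cc(-n2ccnc2)ccc1C` gives > 30000 nM, which is a limit of the assay and not a number. The only position on the scale so far is therefore (the limit of > 30000 nM in this assay, at which 1 of the 2 values shown sits).

Compound 3 `CCN(c1cccc(-n2ccnc2)c1)c1ccc(C#N)c(Cl)c1` is still to be measured in this assay. It differs from compound 2 by hydrogen in place of methyl on an aromatic carbon, ortho to a large group and para to a 1H-imidazol-1-yl group: hydrogen in place of methyl on an aromatic carbon.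

Within the data shown here, no pair of measured compounds provides a step to calibrate this change. The expectation rests only on compound 2 with its limit of > 30000 nM, and a second limit in this assay is the more likely outcome. The expected change is none beyond the scatter, and the estimated step is an at least 1.2-fold lower number from compound 2 to compound 3 (0.07 log units; that floor lies within the scatter). Compound 3 is estimated at 25000 nM, with an expected range from 8000 nM to 60000 nM.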

Compound 3, half-maximal inhibitory concentration: > 30000 nM
Compound 3 was reported as a limit; the forecaster's own chance of this, stated with the estimate: 65%; middle value at least 1.2-fold (0.07 log units) away from the limit.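

Compound 2 and compound 3 both end at a limit of the assay and not at a number, so no step can be read between them for hydrogen in place of methyl. The only position on the scale remains: the limit of > 30000 nM in this assay, at which 2 of the 3 values shown sit.

The compounds shown leave open whether this change alters activity at all, and which structure would give a readable number.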